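Cyclobutyl in place of cyclopentyl in a cell assay

The compounds below may be only part of what the source reports. "The series", "measured", "known", "first", "only" and "open" are said of these compounds alone.

Measured in a functional assay on PC-12 cells (Rattus norvegicus) for inhibition, read by sulforhodamine B assay; on this read-out lower numbers stand for stronger inhibition and higher numbers for weaker inhibition:
- Compound 1 `O=C1NC(=O)C(Cc2ccc(OCC3CCCCO3)cc2)S1`: > 100000 nM (a limit of the assay)
- Compound 2 `O=C1NC(=O)C(Cc2ccc(OCC3CCCCC3)cc2)S1`: 26000 nM
- Compound 3 `O=C1NC(=O)C(Cc2ccc(OCC3CCCC3)cc2)S1`: 25000 nM

Within the data shown here, compound 3 has only one neighbour with an actual number, and that comparison shows a 1.0-fold lower number from compound 2 to compound 3 (0.02 log units; within the scatter). Compound 3 therefore cannot be separated from that neighbour. The value for compound 1 is a limit and not a number.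

The unmeasured compound 4 `O=C1NC(=O)C(Cc2ccc(OCC3CCC3)cc2)S1` keeps the shared core and changes only the ring: cyclobutyl in place of cyclopentyl on a saturated chain carbon bound to an oxygen on an aromatic ring.

Two measured steps replace oxan-2-yl with a ring of carbon only: an at least 3.8-fold lower number from compound 1 to compound 2 (0.58 log units; beyond the scatter) and an at least 4.0-fold lower number from compound 1 to compound 3 (0.60 log units; beyond the scatter). They say little here, since neither compound 3 nor compound 4 carries oxan-2-yl. The closest guide is the change of carbon ring size, which gave a 1.0-fold lower number from compound 2 to compound 3 (0.02 log units; within the scatter). On these data alone, on that single comparison, no change beyond the scatter is expected in this assay, although a four-membered ring remains untested.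

The expected change is a 1.1-fold higher number from compound 3 to compound 4 (0.05 log units; within the scatter).

The estimate for compound 4 is 28000 nM, with an expected range from 13000 nM to 60000 nM.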

Compound 4, half-maximal inhibitory concentration in the PC-12 assay: > 100000 nM
Compound 4: no number, only a limit (the forecaster's own chance of this, stated with the estimate: 12%); middle value at least 3.5-fold (0.55 log units) from the limit.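

In the PC-12 assay, the size of the carbon ring on a saturated chain carbon bound to an oxygen on an aromatic ring turns out to matter: cyclohexyl and cyclopentyl could not be told apart, yet cyclobutyl gives an at least 4.0-fold higher number from compound 3 to compound 4 (0.60 log units; beyond the scatter) and an at least 3.8-fold higher number from compound 2 to compound 4 (0.58 log units; beyond the scatter). In the PC-12 assay compound 4 gives > 100000 nM, which is a limit of the assay and not a number. In a physicochemical assay for lipophilicity (a higher number here means a more lipophilic compound, a lower number a more polar compound), compound 3 gives 3.38 and compound 4 gives 2.81. The step between compound 1 and compound 4 cannot be read, and the change from cyclopentyl to cyclobutyl also makes the compound more polar in the physicochemical assay, which may or may not account for the weaker inhibition: the measured partition coefficient of compound 3, 3.38, and of compound 4, 2.81, a number 0.57 log units lower (beyond the scatter)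

The compounds shown leave open how far inhibition falls with cyclobutyl, and whether the ring size or the lipophilicity is what counts. Cyclopropyl, or an open chain such as isobutyl, at the same place would help to separate the two, since each would show how inhibition and the partition coefficient move together when the ring is made smaller or opened.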